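The compounds below may be only part of what the source reports. "The series", "measured", "known", "first", "only" and "open" are said of these compounds alone.

Measured in an ADME assay on MDCK cells (Canis lupus familiaris) for cytotoxicity; on this read-out higher numbers stand for lower toxicity in this test and lower numbers for higher toxicity in this test:
- compound 1 `CCN(CC)CN1C(=O)/C(=N/NC(=S)Nc2ccccc2)c2cc(Cl)ccc21`: 3000 nM
- compound 2 `CCN(CC)CN1C(=O)/C(=N/NC(=S)Nc2ccc(Cl)cc2)c2ccccc21`: 400 nM
- compound 3 `CCN(CC)CN1C(=O)/C(=N/NC(=S)Nc2ccc(OC)cc2)c2cc(Cl)ccc21`: 11100 nM

Among these three, compound 3 has the highest number, with compound 1 nearest to it and compound 2 furthest away. The next structure, compound 4 `CCN(CC)CN1C(=O)/C(=N/NC(=S)Nc2ccc(Cl)cc2)c2cc(Cl)ccc21`, has chloro in place of methoxy on an aromatic carbon, para to a large group, so that 4-methoxyphenyl becomes 4-chlorophenyl: chloro in place of methoxy on an aromatic carbon.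

For the measured compounds named here, only one measured step touches this site: a 3.7-fold higher number from compound 1 to compound 3 (0.57 log units; beyond the scatter), a modest rise on putting methoxy in place of hydrogen. Losing the methoxy may therefore give up a rise of about that size, although chloro is not hydrogen and this step can only be a partial guide. The other clue is compound 2, which carries the same 4-chlorophenyl and gives 400 nM. However, it differs from compound 4 elsewhere in the shared core, and no measured step isolates that difference. Together these point to a fall beyond the scatter in this assay, probably somewhat larger than the modest measured step. The expected change is a 7.4-fold lower number from compound 3 to compound 4 (0.87 log units; beyond the scatter). For compound 4 the estimated value is 1500 nM, with an expected range from 400 nM to 5000 nM.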

Compound 4, half-maximal cytotoxic concentration: 2400 nM
Beside the measured number, compound 4's estimate is 1.6-fold (0.20 log units) below it, within the range that was stated.
By their numbers in this assay, from the lowest: compound 2; then compounds 4 and 1 (each within the scatter of the next); then compound 3.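

In this assay, the site para to a large group now has three substituents to compare: a 4.6-fold lower number from compound 3 to compound 4 (0.67 log units; beyond the scatter) shows that chloro does not keep the higher number seen with methoxy, while a 1.3-fold lower number from compound 1 to compound 4 (0.10 log units; within the scatter) puts chloro and hydrogen at this site within the scatter of each other, so that among these compounds only methoxy stands apart there. The same kind of replacement acts differently elsewhere, as chloro in place of hydrogen on an aromatic carbon of the shared core gives a 6.0-fold higher number from compound 2 to compound 4 (0.78 log units; beyond the scatter) and so separates compound 2, which lacks that core chloro, from compound 4, which carries it. Nothing shown here accounts for either difference.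

The only methoxy compound shown, compound 3, also carries the core chloro, so it remains open whether methoxy would bring a similar rise on the core of compound 2. Going by these compounds, it is equally open whether another group at this site, such as ethoxy, an amine or a carboxylic acid, would fall with methoxy or with chloro and hydrogen.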